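Capping a hydroxy group as methoxy: an expected step

This account rests on a few compounds, and the source may have more. Where it says the series, first, only, none or still open, it means among the compounds named here.

Compound 1 `O=C(Nc1cccc(-n2cc(-c3ccncc3)c(-c3cc(O)cc(Cl)c3)n2)c1)Nc1ccc(Cl)c(C(F)(F)F)c1` gives 93% in a functional assay on ACHN cells (Homo sapiens) for inhibition, read by sulforhodamine B assay, with a stated time of 48 h, tested at 0.1 uM; on this read-out lower numbers stand for a stronger effect and higher numbers for a weaker effect at the one concentration tested.
Compound 2 `O=C(Nc1cccc(-n2cc(-c3ccncc3)c(-c3cc(O)cc(Cl)c3)n2)c1)Nc1ccc(Cl)c(Cl)c1` gives 95% in this assay.
Compound 3 `COc1cc(Cl)cc(-c2nn(-c3cccc(NC(=O)Nc4cc(C(F)(F)F)cc(C(F)(F)F)c4)c3)cc2-c2ccncc2)c1` gives 99% in this assay.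

All three numbers are high, meaning a weak effect, and lie within the usual scatter of one another, so compound 2 cannot be set apart from compound 1 or compound 3. Going by the values given here, the only measured step, a number 2 percentage points higher from compound 1 to compound 2 (within the scatter), concerns a different part of the molecule. Compound 4 `COc1cc(Cl)cc(-c2nn(-c3cccc(NC(=O)Nc4ccc(Cl)c(Cl)c4)c3)cc2-c2ccncc2)c1` differs from compound 2 by methyl in place of hydrogen on an oxygen on an aromatic ring. Among the compounds with values here, no measured step covers this change; compound 3 carries the methoxy group but differs elsewhere too, so its value only shows that a methoxy compound also reads high in this assay. The expected step of a number 1 percentage points higher from compound 2 to compound 4 (within the scatter) is therefore none beyond the scatter. Compound 4 is estimated at 96%, between 88% and 103%.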

Compound 4, a percentage reported as activity, at one concentration (the size of the read-out at that concentration, not a potency): 96%
Compound 4: middle estimate and measured number agree at the digits printed, and the stated range covers the measured number.
By their numbers in this assay, from the lowest: compounds 1, 2, 4 and 3 (each within the scatter of the next).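

Going by these compounds alone, the step of a number 1 percentage points higher from compound 2 to compound 4 (within the scatter) in this assay is the first direct reading of hydroxy to methoxy, with the rest of the molecule held the same. It shows that, on this oxygen, methyl and hydrogen cannot be told apart here, and that the free hydroxy group is not needed for the reading seen in compound 2, which is already high and so stands for a weak effect. No evidence available explains this result.

From the compounds shown here alone, whether an amine or a carboxylic acid in place of the hydroxy group, or a longer chain than methyl on the oxygen, would give a number beyond the scatter remains open.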